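This account rests on a few compounds, and the source may have more. Where it says the series, first, only, none or still open, it means among the compounds named here.

Measured in a functional assay on HCT-116 cells (Homo sapiens) for cytotoxicity, read by MTT assay, with a stated time of 72 h; a lower number here means a stronger inhibitor, a higher number a weaker inhibitor:

- Compound 1 `Nc1cccc(Nc2nc3ccccc3nc2S(=O)(=O)c2ccccc2)c1`: 1540 nM
- Compound 2 `O=S(=O)(c1ccccc1)c1nc2ccccc2nc1Nc1ccc(C(F)(F)F)cc1`: 2090 nM

Only these two compounds have numbers in this assay, so compound 1 can be placed against a single neighbour. The step of a 1.4-fold higher number from compound 1 to compound 2 (0.13 log units; within the scatter) lies within the scatter, which means that neither compound can be ranked ahead of the other.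

Compound 3 `Nc1cccc(Nc2nc3ccccc3nc2S(=O)(=O)c2ccc(F)cc2)c1` keeps the core and the 3-aminophenyl group of compound 1 and changes the phenyl to 4-fluorophenyl: fluoro in place of hydrogen on an aromatic carbon. This is fluoro in place of hydrogen on an aromatic carbon, para to a large group.

Within the data shown here, the one measured step bears on this change only indirectly. Among the measured compounds shown here, it replaced 3-aminophenyl with 4-(trifluoromethyl)phenyl on a nitrogen, a different place in the molecule, and no measured step tests a change on the phenyl that compound 3 alters. Even that larger exchange, a 1.4-fold higher number from compound 1 to compound 2 (0.13 log units; within the scatter), stayed within the scatter. No step beyond the scatter is therefore expected, and no direction can be favoured.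

The expected step is a 1.0-fold lower number from compound 1 to compound 3 (0.01 log units; within the scatter). The estimated value for compound 3 is 1500 nM, with an expected range from 600 nM to 3700 nM.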

Compound 3, half-maximal inhibitory concentration: 6790 nM
Estimate against measurement, compound 3: 4.5-fold (0.66 log units) below; measured number above the stated range.
By their numbers in this assay, from the lowest: compounds 1 and 2 (each within the scatter of the next); then compound 3.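

In this assay, among these compounds, this is the first measured change on the phenyl that becomes 4-fluorophenyl, and it gives a 4.4-fold higher number from compound 1 to compound 3 (0.64 log units; beyond the scatter). This place in the molecule therefore responds to substitution: fluoro in place of hydrogen, para to a large group, is enough to give a weaker inhibitor than compound 1. The earlier step, a 1.4-fold higher number from compound 1 to compound 2 (0.13 log units; within the scatter), lay within the scatter despite exchanging a whole group on the nitrogen, so it gave no sign of a change that could be read, whereas this smaller exchange elsewhere in the molecule can be read. Nothing available explains why fluoro has this effect on the cytotoxicity reading.

The compounds shown rest on a single substituent at this place, so they leave open whether the weaker reading belongs to fluoro itself or would also follow from chloro, a methoxy group or an amine there. They also leave open whether fluoro would have a similar effect on the phenyl when the 3-aminophenyl group is replaced by 4-(trifluoromethyl)phenyl, as in compound 2.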